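The source may report more compounds than this note shows. Statements on the series, on what has been measured and on what is new or still open speak of the compounds shown alone.

Compound 2 `O=C(N/N=C/c1cccc(Cl)c1Cl)Nc1cc2c(Nc3ccc(F)c(Cl)c3)ncnc2cc1O[C@H]1CCOC1` gives 27400 nM in a functional assay on PC-3 cells (Homo sapiens) for cytotoxicity, read by MTT assay, with a stated time of 72 h (on this read-out higher numbers stand for weaker inhibition and lower numbers for stronger inhibition), the highest of the two numbers recorded there; compound 3 `O=C(N/N=C/c1ccc(O)cc1O)Nc1cc2c(Nc3ccc(F)c(Cl)c3)ncnc2cc1O[C@H]1CCOC1` gives 7540 nM, and compound 1 `O=C(N/N=C/c1ccc(F)cc1)Nc1cc2c(Nc3ccc(F)c(Cl)c3)ncnc2cc1O[C@H]1CCOC1` is reported as "not active" (no number reported). Compound 4 `CCN(CC)c1ccc(/C=N/NC(=O)Nc2cc3c(Nc4ccc(F)c(Cl)c4)ncnc3cc2O[C@H]2CCOC2)c(O)c1` differs from compound 2 by 4-(diethylamino)-2-hydroxyphenyl in place of 2,3-dichlorophenyl on a carbon with a double bond to nitrogen. Going by the values given here, the one step that bears on this is a 3.6-fold lower number from compound 2 to compound 3 (0.56 log units; beyond the scatter), where a phenyl carrying hydroxyl groups replaced the same dichlorophenyl. Compound 4 also carries a hydroxyl on that ring, so a step of similar direction and size is expected, with the step from compound 2 to compound 4 estimated at a 3.0-fold lower number from compound 2 to compound 4 (0.48 log units; beyond the scatter). Compound 4 is therefore expected to give about 9000 nM, within a range from 3000 nM to 30000 nM.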

Compound 4, half-maximal inhibitory concentration: 4590 nM
Estimate against measurement, compound 4: 2.0-fold (0.29 log units) above, and the stated range covers the measured number.
By their numbers in this assay, from the lowest: compounds 4 and 3 (each within the scatter of the next); then compound 2.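

In this assay, a second ring bearing a hydroxyl at the carbon with a double bond to nitrogen also improves on 2,3-dichlorophenyl, now with a 6.0-fold lower number from compound 2 to compound 4 (0.78 log units; beyond the scatter). Diethylamino in place of hydroxy on an aromatic carbon gives a 1.6-fold lower number from compound 3 to compound 4 (0.22 log units; within the scatter), so this larger group leaves the read-out within the usual variation of compound 3. No evidence is available to explain either step. On these data alone, it remains open what a ring carrying diethylamino without any hydroxyl would give. As far as these compounds go, it is also open whether a morpholine or a carboxylic acid on that aromatic carbon would match compound 4.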